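The compounds below may be only part of what the source reports. "The series", "measured", "known", "first", "only" and "open" are said of these compounds alone.

Working notes on the series. Three compounds share one core and differ only in the substituent on a saturated ring carbon: compound 1 `O=C1NC(=O)/C(=C\c2ccc(OCC(=O)N3N=C(c4ccc(F)cc4)CC3c3ccco3)cc2)S1`, compound 2 `O=C1NC(=O)/C(=C\c2ccc(OCC(=O)N3N=C(c4ccc(F)cc4)CC3c3ccc(C(F)(F)F)cc3)cc2)S1` and compound 3 `Cc1ccc(C2CC(c3ccc(F)cc3)=NN2C(=O)COc2ccc(/C=C3/SC(=O)NC3=O)cc2)cc1`. All three were tested in an assay on cells for inhibition of histone deacetylase 8 (Homo sapiens), read by fluorescence, with a stated time of 30 min; a lower number here means a stronger inhibitor, a higher number a weaker inhibitor. In this assay compound 1 gives only a limit, > 50000 nM. Compound 2 likewise gives only a limit in this assay, > 50000 nM. Compound 3 too returns only a limit in this assay, > 50000 nM. Because every value sits at the limit of > 50000 nM in this assay, at which 3 of the 3 values shown sit, none of the steps among them can be sized: a step that the two limits leave unreadable from compound 1 to compound 2, a step that the two limits leave unreadable from compound 1 to compound 3 and a step that the two limits leave unreadable from compound 2 to compound 3 are all unreadable. Compound 3 therefore stands nowhere distinguishable from compounds 1 and 2 on the numbers shown.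

The next compound, compound 4 `Cc1ccc(C2CC(c3ccc(F)cc3F)=NN2C(=O)COc2ccc(/C=C3/SC(=O)NC3=O)cc2)cc1`, is compound 3 with one change: fluoro in place of hydrogen on an aromatic carbon. Going by the values given here, no measured step bears on this change, and the steps that exist are all unreadable against the limit. The expected step in this assay from compound 3 to compound 4 is therefore estimated as a step that the limit leaves unreadable from compound 3 to compound 4, with a high chance that only another limit results. Compound 4 is expected to give about 100000 nM in this assay, within 20000 nM to 500000 nM.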

Compound 4, half-maximal inhibitory concentration: > 50000 nM
Compound 4 gave a limit, no number; the forecaster's own chance of this, stated with the estimate: 85%; the middle value is on the limit's open side.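

In this assay compound 4 also gives only a limit (> 50000 nM). No step can be read from compound 3 to compound 4, and the series gives no sized comparison: the limit of > 50000 nM in this assay, at which 4 of the 4 values shown sit. The compounds shown leave open whether fluoro in place of hydrogen, or any other substituent change here, alters inhibition at all.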